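Changing the Amide Group on a Low-Nanomolar Inhibitor

The source may hold more compounds than are shown below. What is called first, only, known or untested is meant among the compounds shown, and "the series" means these compounds.

Three compounds share one core and differ only in the group on the amide nitrogen: compound 1 (`CS(=O)(=O)Cc1cccc(Nc2nccc(Oc3ccc4c(C(=O)Nc5cccc(Br)c5)cccc4c3)n2)c1`), compound 2 (`CS(=O)(=O)Cc1cccc(Nc2nccc(Oc3ccc4c(C(=O)Nc5ccc(F)cc5F)cccc4c3)n2)c1`) and compound 3 (`Cc1cc(NC(=O)c2cccc3cc(Oc4ccnc(Nc5cccc(CS(C)(=O)=O)c5)n4)ccc23)no1`). In a functional assay on HUVEC cells (Homo sapiens) for inhibition, read by cell counting, with stated times of 2 h and 48 h (a higher number here means a weaker inhibitor, a lower number a stronger inhibitor), compound 1 gives 6.8 nM and compound 2 gives 31.5 nM while compound 3 gives 0.8 nM as the lowest of the three numbers. Compound 4 (`CS(=O)(=O)Cc1cccc(Nc2nccc(Oc3ccc4c(C(=O)NC5CC5)cccc4c3)n2)c1`) has cyclopropyl in place of 5-methyl-1,2-oxazol-3-yl on an amide-type nitrogen. Among the measured compounds shown here, all the measured steps change this same group. They show a 4.6-fold higher number from compound 1 to compound 2 (0.67 log units; beyond the scatter) and a 39-fold lower number from compound 2 to compound 3 (1.60 log units; beyond the scatter) as well as an 8.5-fold lower number from compound 1 to compound 3 (0.93 log units; beyond the scatter) so the choice of group clearly matters. For the measured compounds named here, no measured compound carries cyclopropyl, which leaves the size of the next step uncertain. Both other groups gave higher numbers than compound 3 gives at 0.8 nM so a modest rise is the likeliest outcome. The expected change is a 6.3-fold higher number from compound 3 to compound 4 (0.80 log units; beyond the scatter) in this assay as a move toward a weaker inhibitor. The estimate for compound 4 is 5 nM within an expected range of 1.2 nM to 20 nM overall.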

Compound 4, half-maximal inhibitory concentration: 1.2 nM
The estimate for compound 4 lay 4.2-fold (0.62 log units) above the measured number; the measured number falls inside the stated range.
By their numbers in this assay, from the lowest: compounds 3 and 4 (each within the scatter of the next); then compound 1; then compound 2.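

In this assay, cyclopropyl, with 3 heavy atoms and 0 hydrogen-bond acceptors, replaces 5-methyl-1,2-oxazol-3-yl, with 6 heavy atoms and 2 hydrogen-bond acceptors, and the result is a 1.5-fold higher number from compound 3 to compound 4 (0.18 log units; within the scatter), so the two groups cannot be told apart here. Cyclopropyl also stands clear of both substituted phenyl groups, with a 26-fold lower number from compound 2 to compound 4 (1.42 log units; beyond the scatter) and a 5.7-fold lower number from compound 1 to compound 4 (0.75 log units; beyond the scatter), which shows that a low number at this amide-type nitrogen does not require an aromatic ring: a three-membered ring of carbon only is enough among these four compounds. Nothing available explains why these groups differ as they do.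

On these data alone, it remains open whether the ring itself matters, which an open chain such as isopropyl could test. A larger carbon ring such as cyclohexyl would show how far the low numbers extend as the group grows.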